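This account rests on a few compounds, and the source may have more. Where it says the series, first, only, none or still open, it means among the compounds named here.

Compound 1 `CC1=NN(C(=O)c2ccc(C)cc2)C(c2ccccc2O)C1` gives 40600 nM in a functional assay on PC-3 cells (Homo sapiens) for cytotoxicity, read by MTT assay, with a stated time of 48 h; on this read-out higher numbers stand for weaker inhibition and lower numbers for stronger inhibition. Compound 2 `CCC(=O)N1N=C(C)CC1c1cc(Br)ccc1O` gives 37800 nM in this assay; the two numbers lie within the usual scatter of each other, so neither stands apart. Compound 3 `CC1=NN(C(=O)c2ccc(C)cc2)C(c2cc(Br)ccc2O)C1` carries 4-methylphenyl in place of ethyl on a carbonyl carbon, and so brings together the acyl group of compound 1 and the remainder of compound 2. Going by the values given here, no measured pair differs only in this way, so no step is known. Since both measured numbers sit close together, compound 3 is expected to fall in the same region, estimated at 40000 nM with a range of 15000 nM to 100000 nM. The expected step of a 1.1-fold higher number from compound 2 to compound 3 (0.02 log units; within the scatter) should stay within the scatter.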

Compound 3, half-maximal inhibitory concentration: 41200 nM
Estimate against measurement, compound 3: 1.0-fold (0.01 log units) below; the range from low to high includes it.
By their numbers in this assay, from the lowest: compounds 2, 1 and 3 (each within the scatter of the next).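

In this assay, 4-methylphenyl in place of ethyl on a carbonyl carbon gives a 1.1-fold higher number from compound 2 to compound 3 (0.04 log units; within the scatter) and so does not separate these two groups at this position, even though the new group brings an aromatic ring. Bromo in place of hydrogen on an aromatic carbon gives a 1.0-fold higher number from compound 1 to compound 3 (0.01 log units; within the scatter) and so also leaves the number unmoved with 4-methylphenyl on the carbonyl carbon. On these data alone, whether an amine, a carboxylic acid or a longer chain on that carbonyl carbon would shift the number stays open. Nothing at hand bears on why these values stay together.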